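The compounds below may be only part of what the source reports. "The series", "measured", "known", "first", "only" and "open" are said of these compounds alone.

Compound 1 `CCOC(=O)NCCOc1ccc(CC2CCCCC2=O)cc1` and compound 2 `CCOC(=O)NCCOc1ccc(C[C@@H]2CCCC[C@@H]2O)cc1` share one core and differ in the ring that hangs from the saturated chain carbon bound to an aromatic carbon. In a functional assay on the whole organism for inhibition, with Galleria mellonella as the target (a lower number here means that less compound is needed, a higher number that more compound is needed for the effect), compound 1 gives 0.0002 mg/kg, and compound 2 gives 0.0008 mg/kg. Within the data shown here, the step of a 4.0-fold higher number from compound 1 to compound 2 (0.60 log units; beyond the scatter) puts compound 2 at the highest number of the two measured so far, with compound 1 as its only neighbour.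

Compound 3 `CCOC(=O)NCCOc1ccc(C[C@H]2CCCC[C@@H]2O)cc1` is the next compound, and it is not a change of atoms: the two compounds have the same atoms and bonds and differ only in configuration as drawn: 1 of 2 stereo elements differ; a stereocentre at a saturated ring carbon is drawn S in compound 2 and R in compound 3. Among the measured compounds shown here, none of the measured steps speaks to this. The one step shown, from compound 1 to compound 2, exchanged an oxo group for a hydroxyl and tells nothing about turning one ring carbon around while keeping the other as it was. The expectation for compound 3 therefore rests only on the value of compound 2, 0.0008 mg/kg, as the nearest number, and the step is expected to be no change at the digits printed from compound 2 to compound 3 (within the scatter) with little confidence in either direction. Compound 3 is estimated to give 0.0008 mg/kg in this assay, with a range from 0.00025 mg/kg to 0.0025 mg/kg.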

Compound 3, dose for half-maximal effect: 0.0008 mg/kg
Compound 3: middle estimate and measured number agree at the digits printed; the measured number falls inside the stated range.
By their numbers in this assay, from the lowest: compound 1; then compounds 2 and 3 (each within the scatter of the next).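

In this assay the new result gives no change at the digits printed from compound 2 to compound 3 (within the scatter), so with the other stereocentre kept as drawn, the configuration at this saturated ring carbon does not separate these two hydroxyl compounds. The earlier step had shown the exchange of 2-oxocyclohexyl for 2-hydroxycyclohexyl for one drawn configuration only; the same exchange now gives a 4.0-fold higher number from compound 1 to compound 3 (0.60 log units; beyond the scatter), which matches in size the earlier 4.0-fold higher number from compound 1 to compound 2 (0.60 log units; beyond the scatter) and holds for both drawn forms of the hydroxyl compound. The reading of compounds 2 and 3 as a pure stereo comparison rests on one point: the fact that compounds 2 and 3 differ only in the configuration as drawn

The compounds shown leave open whether the second stereocentre can be turned around with the same outcome, as compounds 2 and 3 share its drawn configuration. They also leave open how an amine or a methoxy group in place of the hydroxyl on the cyclohexyl ring would compare with the oxo group of compound 1 and the hydroxyl group of compounds 2 and 3.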